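Defining the dioxolane stereocentre within the series

A few compounds are considered here, and "the series" means these few. Any claim that something is new, unique, unknown or untested is made for them only; others in the source may bear on it.

Compound 1 `O=C1c2c[n+]([O-])c3ccccc3c2C(=O)c2c1c1ccccc1n2Cc1cn(C[C@@H](O)CO)nn1` and compound 2 `CC1(C)OCC(Cn2cc(Cn3c4c(c5ccccc53)C(=O)c3c[n+]([O-])c5ccccc5c3C4=O)nn2)O1` share one core and differ only in the side chain. In a toxicity assay on HEK-293T cells (Homo sapiens) for cytotoxicity, read by MTT assay, with a stated time of 72 h (a higher number here means a weaker inhibitor, a lower number a stronger inhibitor), compound 1 gives 2030 nM, while compound 2 gives 5510 nM; the step is a 2.7-fold higher number from compound 1 to compound 2 (0.43 log units; beyond the scatter). On these two numbers compound 2 stands as the higher of the pair.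

Compound 3 `CC1(C)OC[C@H](Cn2cc(Cn3c4c(c5ccccc53)C(=O)c3c[n+]([O-])c5ccccc5c3C4=O)nn2)O1` is now to be measured in this assay. Its difference from compound 2: the two compounds have the same atoms and bonds; at least one stereo element is drawn with a configuration in one of them and without one in the other: 1 of 1 stereo elements differ; a stereocentre at a saturated ring carbon is drawn without a configuration in compound 2 and S in compound 3. Within the data shown here, no measured step concerns a stereocentre; the single available step, a 2.7-fold higher number from compound 1 to compound 2 (0.43 log units; beyond the scatter), exchanges one group for another rather than fixing a configuration, so it does not bear on this change. With nothing in the data to separate one configuration from the undefined material, the expected step in this assay is a 1.0-fold lower number from compound 2 to compound 3 (0.00 log units; within the scatter), none beyond the scatter. Compound 3 is therefore expected to give 5500 nM, with a range of 2500 nM to 12000 nM.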

Compound 3, half-maximal inhibitory concentration: 100 nM
Compound 3: middle estimate off by 55-fold (1.74 log units), on the high side; the whole stated range lies above it.
By their numbers in this assay, from the lowest: compound 3; then compound 1; then compound 2.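

In this assay the configuration at the saturated ring carbon proves to be a strong determinant of the number: a 55-fold lower number from compound 2 to compound 3 (1.74 log units; beyond the scatter) is a large step for a change that leaves atoms and bonds untouched. The step can be tied to one thing only, the configuration drawn at that carbon: the fact that one of compounds 2 and 3 is drawn with a defined configuration and the other without, at the place where they differ. The side-chain comparison also changes direction, since a 2.7-fold higher number from compound 1 to compound 2 (0.43 log units; beyond the scatter) pointed to a higher number with 2,2-dimethyl-1,3-dioxolan-4-yl in place of 1,2-dihydroxyethyl, whereas the S form gives a 20-fold lower number from compound 1 to compound 3 (1.31 log units; beyond the scatter) for the same exchange of groups.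

The compounds shown leave open where the R configuration at this carbon would stand relative to compound 2 and compound 3. From the compounds shown here alone, it also remains open whether an amine or a longer chain in place of the 2,2-dimethyl-1,3-dioxolan-4-yl group would keep the low number of compound 3.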